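A few compounds are considered here, and "the series" means these few. Any claim that something is new, unique, unknown or untested is made for them only; others in the source may bear on it.

Compound 1, with the structure `O=C(CN(c1ncnc2c1ncn2C1CCCCO1)C1CC1)NCC(=O)OCc1ccccc1`, was tested in a functional assay on the whole organism (Tail, strain ICR) with Mus musculus as the target, in the tail flick test, with a stated time of 150 min, at a dose of 25 umol/kg by the oral route (on this read-out higher numbers stand for a stronger effect at the one dose given and lower numbers for a weaker effect), where compound 1 gives 7.26%. Within the data shown here, the only other measured compound, compound 2, of structure `C[C@@H](O)[C@H](NC(=O)CN(c1nc(Cl)nc2[nH]cnc12)C1CC1)C(=O)OCc1ccccc1`, gives in this assay a reading of 12.8%. The two numbers lie within the usual scatter of each other, so compound 1 is simply one of two low readings and nothing more can be said about how the two compounds stand against one another. Among the measured compounds shown here, no single-point step between measured compounds exists in this set.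

Compound 3, of structure `NC(=O)C[C@H](NC(=O)CN(c1ncnc2c1ncn2C1CCCCO1)C1CC1)C(=O)OCc1ccccc1`, has not yet been measured in this assay. It differs from compound 1 by carbamoylmethyl in place of hydrogen on a saturated chain carbon bound to an amide-type nitrogen and a carbonyl carbon. For the measured compounds named here, with no measured step to lean on, the size of the move from compound 1 to compound 3 cannot be anchored in the data. Both measured compounds sit low, and the expectation is that compound 3 behaves similarly, with a step of a number 2.7 percentage points higher from compound 1 to compound 3 (within the scatter) that is not expected to go beyond the scatter in either direction. Compound 3 is accordingly estimated at 10%, within a range from 2% to 22%.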

Compound 3, a percentage reported as activity, at one dose (the size of the read-out at that dose, not a potency): 21.7%
Compound 3: middle estimate off by 11.7 percentage points, on the low side; low and high end bracket the measured number.
By their numbers in this assay, from the lowest: compounds 1, 2 and 3 (each within the scatter of the next, the first and the last beyond it).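

In this assay, among these compounds, the only step that can be read shows that the saturated chain carbon bound to an amide-type nitrogen and a carbonyl carbon is a place where a change moves the read-out: carbamoylmethyl in place of hydrogen gives a number 14.4 percentage points higher from compound 1 to compound 3 (beyond the scatter). The step is modest but lies beyond the scatter, something the earlier two compounds could not show, as their numbers lay within the scatter of each other and they differ in more than one place. Nothing at hand bears on why this change raises the reading.

On these data alone, it remains open whether the rise belongs to the carbamoylmethyl group itself or would come with other groups on the same carbon, such as a plain methyl, a carboxylic acid, an amine or a longer chain ending in the same amide. As far as these compounds go, it is also open whether the same change would give a step of like size on a core other than that of compound 1, and whether the step would hold at other doses or times.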